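Three Level Aryl Variants and an Untested Bromo Analogue

The source may report more compounds than this note shows. Statements on the series, on what has been measured and on what is new or still open speak of the compounds shown alone.

In a functional assay on LoVo cells (Homo sapiens) for inhibition, read by MTT assay, with a stated time of 24 h (on this read-out lower numbers stand for stronger inhibition and higher numbers for weaker inhibition), the measured compounds are:
compound 1, `CC1(C)[C@H]2CC[C@]1(C)N(Cc1cn(-c3cccc(Cl)c3)nn1)C(=O)C2`: 70 nM
compound 2, `COc1ccccc1-n1cc(CN2C(=O)C[C@@H]3CC[C@@]2(C)C3(C)C)nn1`: 70 nM
compound 3, `COc1ccc(-n2cc(CN3C(=O)C[C@@H]4CC[C@@]3(C)C4(C)C)nn2)cc1`: 70 nM

Compound 3 stands level with compounds 1 and 2 on this read-out. The three measured steps all stay within the scatter: no change at the digits printed from compound 1 to compound 2 (within the scatter), no change at the digits printed from compound 1 to compound 3 (within the scatter) and no change at the digits printed from compound 2 to compound 3 (within the scatter). Taken together they show that exchanging the group on the aromatic nitrogen among 3-chlorophenyl, 2-methoxyphenyl and 4-methoxyphenyl leaves the half-maximal inhibitory concentration where it was.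

Compound 4, `CC1(C)[C@H]2CC[C@]1(C)N(Cc1cn(-c3ccc(Br)cc3)nn1)C(=O)C2`, has not yet been measured. It differs from compound 3 in one place: bromo in place of methoxy on an aromatic carbon. Going by the values given here, no measured pair swaps a methoxy for a halogen at the same position, so the closest guide is the pair of compound 1 and compound 3, where a chlorophenyl and a methoxyphenyl gave no change, and the pair of compound 2 and compound 3, where moving the methoxy gave none either.

On that basis compound 4 is expected to show no step beyond the scatter, no change at the digits printed from compound 3 to compound 4 (within the scatter). Compound 4 is therefore estimated at 70 nM, with a range from 35 nM to 140 nM.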

Compound 4, half-maximal inhibitory concentration: 60 nM
For compound 4 the middle estimate is 1.2-fold (0.07 log units) above the measured one; measured number inside the range.
By their numbers in this assay, from the lowest: compounds 4, 1, 2 and 3 (each within the scatter of the next).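

In this assay, the change from 4-methoxyphenyl to 4-bromophenyl gives a 1.2-fold lower number from compound 3 to compound 4 (0.07 log units; within the scatter), which lies within the scatter, so this position, on an aromatic carbon para to a large group, tolerates an exchange of group type and not only a shift of the group around the ring: methoxy, with its 1 hydrogen-bond acceptor, leaves, and bromo, with 0 hydrogen-bond acceptors, enters, and the read-out holds. Going by these compounds alone, the two wider exchanges on the aromatic nitrogen agree, with a 1.2-fold lower number from compound 2 to compound 4 (0.07 log units; within the scatter) and a 1.2-fold lower number from compound 1 to compound 4 (0.07 log units; within the scatter), both also within the scatter, so 4-bromophenyl joins 3-chlorophenyl, 2-methoxyphenyl and 4-methoxyphenyl as one level set with no compound among the four standing apart. Nothing given here accounts for this flat result.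

From the compounds shown here alone, all four compounds carry a halogen or a methoxy on the phenyl ring, so it remains open whether an amine, a carboxylic acid or a longer alkoxy chain at this position would stay level with them. Going by these compounds, it also remains open whether a plain phenyl, with no group on the ring at all, would hold the same value.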